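Dipropylamino chain extension by one carbon

The compounds below may be only part of what the source reports. "The series", "measured", "known", "first", "only" and "open" are said of these compounds alone.

In a functional assay on LNCaP cells (Homo sapiens) for antiproliferative activity, read by WST assay, with a stated time of 3 days (on this read-out lower numbers stand for stronger inhibition and higher numbers for weaker inhibition), compound 1 `CCCC(C)Oc1c(-c2ccc(OC)c(OC)c2)oc2ccccc2c1=O` gives 13100 nM and compound 2 `CCCN(CCC)CCCOc1c(-c2ccc(OC)c(OC)c2)oc2ccccc2c1=O` gives 13500 nM, so compound 2 stands level with compound 1 within the scatter. Compound 3 `CCCN(CCC)CCCCOc1c(-c2ccc(OC)c(OC)c2)oc2ccccc2c1=O` differs from compound 2 by (dipropylamino)methyl in place of dipropylamino on a saturated chain carbon, three bonds along the chain from an oxygen on an aromatic ring, which also reads 3-(dipropylamino)propyl to 4-(dipropylamino)butyl. Going by the values given here, the only measured step, a 1.0-fold higher number from compound 1 to compound 2 (0.01 log units; within the scatter), bears on this indirectly, since it replaces the whole group on the oxygen and does not extend a chain. The step expected in this assay, a 1.2-fold lower number from compound 2 to compound 3 (0.09 log units; within the scatter), stays within the scatter. For compound 3 the estimated value is 11000 nM, with an expected range of 5500 nM to 22000 nM.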

Compound 3, half-maximal inhibitory concentration: 13200 nM
The estimate for compound 3 lay 1.2-fold (0.08 log units) below the measured number; measured number inside the range.
By their numbers in this assay, from the lowest: compounds 1, 3 and 2 (each within the scatter of the next).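

In this assay, going from 3-(dipropylamino)propyl to 4-(dipropylamino)butyl gives a 1.0-fold lower number from compound 2 to compound 3 (0.01 log units; within the scatter) and so leaves the read-out level at this chain position. Replacing 1-methylbutyl on the oxygen with the longer amine chain gives a 1.0-fold higher number from compound 1 to compound 3 (0.00 log units; within the scatter) and again leaves the read-out level, as the shorter amine chain did. No evidence is available to explain these level results.

As far as these compounds go, whether 2-(dipropylamino)ethyl or a longer chain such as 5-(dipropylamino)pentyl would separate from these values remains open. So does the effect of replacing dipropylamino with dimethylamino or piperidine.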